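Plasma protein binding: chloro to methyl on the aryl ring

This account rests on a few compounds, and the source may have more. Where it says the series, first, only, none or still open, it means among the compounds named here.

Working notes on the series. Three compounds carry measured values in an ADME assay on a cell-free system (plasma, Rattus norvegicus) for protein binding. Compound 1 `Cc1ccc(-c2cc(C(=O)N[C@H](C)c3ccc(F)cn3)cc(-n3nccn3)c2)nc1` gives 97.4%. Compound 2 `C[C@@H](NC(=O)c1cc(-c2ccc(Cl)cc2)cc(C(C)(C)O)c1)c1ccc(C(F)(F)F)[n+]([O-])c1` gives 97.4%, level with compound 1 at the digits shown; together these two hold the lowest unbound fraction of the three. Compound 3 `Cc1ccc(-c2cc(C(=O)N[C@H](C)c3ccc(C(F)(F)F)nc3)cc(C(C)(C)O)c2)nc1` gives 95.2%, and the gap between compound 2 and compound 3 lies within the scatter. Among the measured compounds shown here, no pair among the measured compounds differs in a single place, so no measured single step exists to lean on.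

Compound 4 `Cc1ccc(-c2cc(C(=O)N[C@H](C)c3ccc(C(F)(F)F)[n+]([O-])c3)cc(C(C)(C)O)c2)cc1` awaits measurement in this assay. Relative to compound 2 the change is methyl in place of chloro on an aromatic carbon of a six-membered aromatic ring of carbon only. For the measured compounds named here, with no measured step for this exchange, the expected step a 1.3-fold higher unbound fraction from compound 2 to compound 4 (0.13 log units; within the scatter) is small, pointing toward a slightly lower bound percentage but not beyond the scatter. Compound 4 is therefore estimated at 96.5%, with a range from 93% to 98.5%.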

Compound 4, plasma protein binding: 95.4%
The estimate for compound 4 lay 1.3-fold (0.12 log units) (unbound fraction) below the measured number; low and high end bracket the measured number.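

In this assay, among the compounds shown here, the exchange of 4-chlorophenyl to 4-methylphenyl now has a measured step, a 1.8-fold higher unbound fraction from compound 2 to compound 4 (0.25 log units; within the scatter), where the earlier compounds offered no pair differing in one place. At this position, para to a large group, methyl and chloro therefore cannot be told apart in this read-out, and this holds for this single pair with the rest of compound 2 unchanged. Nothing available bears on the origin of this step.

From the compounds shown here alone, whether a carboxylic acid, an amine or a methoxy group at the same position would give a step beyond the scatter remains open. Also open, going by these compounds, is whether the chloro-to-methyl exchange gives a similar step when the other groups on the shared core differ.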